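Chloro Substitution on Two Rings of an Oxime Ether Series

The source may hold more compounds than are shown below. What is called first, only, known or untested is meant among the compounds shown, and "the series" means these compounds.

Compound 1 `O=[N+]([O-])c1cc(C(F)(F)F)cc([N+](=O)[O-])c1Oc1ccc(Cl)cc1/C=N\OCc1ccccc1F` gives 1110 nM in a functional assay on MCF7 cells (Homo sapiens) for antiproliferative activity, read by MTT assay, with a stated time of 48 h; a lower number here means a stronger inhibitor, a higher number a weaker inhibitor. Compound 2 `O=[N+]([O-])c1cc(C(F)(F)F)cc([N+](=O)[O-])c1Oc1c(Cl)cc(Cl)cc1/C=N\OCc1ccccc1F` carries chloro in place of hydrogen on an aromatic carbon, placed ortho to a large group, meta to a chloro group and meta to a large group, and in this assay compound 2 gives 800 nM; the step is a 1.4-fold lower number from compound 1 to compound 2 (0.14 log units; within the scatter). Compound 3 `O=[N+]([O-])c1cc(C(F)(F)F)cc([N+](=O)[O-])c1Oc1c(Cl)cc(Cl)cc1/C=N/OCc1ccccc1Cl` gives 1960 nM; the step is a 2.5-fold higher number from compound 2 to compound 3 (0.39 log units; beyond the scatter). The difference between the core of compound 3 and that of compound 1 is not broken down here. Compound 4 `O=[N+]([O-])c1cc(C(F)(F)F)cc([N+](=O)[O-])c1Oc1c(Cl)cc(Cl)cc1/C=N/OCc1ccc(Cl)cc1Cl` carries chloro in place of hydrogen on an aromatic carbon, here meta to a chloro group and para to a large group, the same kind of change as between compound 1 and compound 2 but at another place. Because a 1.4-fold lower number from compound 1 to compound 2 (0.14 log units; within the scatter) lay within the scatter, the expected step is a 1.3-fold lower number from compound 3 to compound 4 (0.12 log units; within the scatter). Compound 4 is estimated at 1500 nM, between 600 nM and 4000 nM.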

Compound 4, half-maximal inhibitory concentration: 1030 nM
Beside the measured number, compound 4's estimate is 1.5-fold (0.16 log units) above it, within the range that was stated.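

The step of chloro in place of hydrogen reads a 1.9-fold lower number from compound 3 to compound 4 (0.28 log units; within the scatter) in this assay, and it agrees with the earlier step: the same change on two cores in this assay, a 1.4-fold lower number (0.14 log units; within the scatter) from compound 1 to compound 2 and a 1.9-fold lower number (0.28 log units; within the scatter) from compound 3 to compound 4, 1.4-fold (0.14 log units) apart, within the scatter of two such steps. The change therefore stays within the scatter on both cores, although it stands at a different place in each. This shows no real gain from chloro on either core and says nothing about other cores, and the larger group exchange, a 1.3-fold higher number from compound 2 to compound 4 (0.11 log units; within the scatter), also stays within the scatter.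

The compounds shown leave open how a methoxy group, a nitrile or an amine would compare with chloro on the 2-chlorobenzyl group. They also leave open whether these steps would hold on any other core.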